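Trimming the chain on the aromatic nitrogen to methyl

The source may report more compounds than this note shows. Statements on the series, on what has been measured and on what is new or still open speak of the compounds shown alone.

Three analogues sharing one core have been tested in a functional assay on MCF7 cells (Homo sapiens) for antiproliferative activity; a lower number here means a stronger inhibitor, a higher number a weaker inhibitor. Compound 1 `COc1cc(Cc2nc3c(N)ncnc3n2CC(C)C)cc(OC)c1OC` gives 97700 nM. Compound 2 `COc1cc(Cc2nc3c(N)ncnc3n2CC2(C)CC2)cc(OC)c1OC` gives 112000 nM. Compound 3 `COc1cc(Cc2nc3c(N)ncnc3n2CCOC(C)C)cc(OC)c1OC` gives 38900 nM, the lowest of the three numbers; compound 1 is nearest, compound 2 furthest. The steps to it are a 2.5-fold lower number from compound 1 to compound 3 (0.40 log units; beyond the scatter) and a 2.9-fold lower number from compound 2 to compound 3 (0.46 log units; beyond the scatter), and between the other two the step is a 1.1-fold higher number from compound 1 to compound 2 (0.06 log units; within the scatter).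

Compound 4 `COc1cc(Cc2nc3c(N)ncnc3n2C)cc(OC)c1OC` is yet to be measured. Its change from compound 3 is hydrogen in place of isopropoxymethyl on a saturated chain carbon bound to an aromatic nitrogen, so the whole 2-isopropoxyethyl chain is cut back to methyl. For the measured compounds named here, no measured pair removes the chain entirely; the only bearing steps show that isopropoxymethyl on that carbon gave modestly lower numbers than isopropyl or 1-methylcyclopropyl. Going to hydrogen is expected to undo that gain, with the step of a 2.6-fold higher number from compound 3 to compound 4 (0.41 log units; beyond the scatter) estimated to run upward, modest in size. Compound 4 is therefore expected to give about 100000 nM, in the range 40000 nM to 300000 nM.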

Compound 4, half-maximal inhibitory concentration: 70800 nM
Beside the measured number, compound 4's estimate is 1.4-fold (0.15 log units) above it; measured number inside the range.
By their numbers in this assay, from the lowest: compounds 3, 4, 1 and 2 (each within the scatter of the next, the first and the last beyond it).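

In this assay, cutting the 2-isopropoxyethyl chain back to methyl gives a 1.8-fold higher number from compound 3 to compound 4 (0.26 log units; within the scatter), so the removal of isopropoxymethyl at this position cannot be told apart from keeping it, although that group had set compound 3 apart from compound 1 and compound 2. Hydrogen in place of the other two groups is equally unresolved, with a 1.4-fold lower number from compound 1 to compound 4 (0.14 log units; within the scatter) and a 1.6-fold lower number from compound 2 to compound 4 (0.20 log units; within the scatter), which means compound 4 cannot be ordered against any of the three larger-chain compounds. Nothing available explains this result.

The compounds shown leave open whether an amine or a carboxylic acid in place of isopropoxymethyl on that saturated chain carbon would move the number clearly away from this group of values. They also leave open whether a chain with carbon in place of the oxygen of compound 3 would keep its separation from compound 1.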